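The source may report more compounds than this note shows. Statements on the series, on what has been measured and on what is new or still open speak of the compounds shown alone.

Measured compounds and their values:

- compound 1, `COc1ccc(/C=C/c2ccc(F)cc2)cc1`: > 200 ug/mL
- compound 2, `Cc1ccc(/C=C/c2ccc(N(C)C)cc2)cc1`: > 200 ug/mL

In a functional assay on MOLT-4 cells (Homo sapiens), read by cell counting, with a stated time of 72 h (a higher number here means a weaker inhibitor, a lower number a stronger inhibitor), compound 1 gives > 200 ug/mL, and that value is a limit of the assay rather than a measured number. Compound 2 gives > 200 ug/mL in this assay, which is again a limit and not a number. So compound 2 stands where every value shown stands: at the limit of > 200 ug/mL in this assay, at which 2 of the 2 values shown sit. Among the measured compounds shown here, no step between two measured compounds is available, and the two values together only show that neither compound reached a measurable inhibition.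

Compound 3, `COc1ccc(/C=C/c2ccc(C)cc2)cc1`, differs from compound 2 in one place: methoxy in place of dimethylamino on an aromatic carbon. Compound 1 already carries a methoxy group on one of its rings and sits at the limit, so there is nothing in the numbers that points to a stronger inhibitor once a methoxy replaces the dimethylamino group. No step beyond the usual scatter is expected in this assay, in either direction.

Compound 3 is therefore expected to give 200 ug/mL in this assay, within 100 ug/mL to 400 ug/mL, most likely reported once more as a limit; this estimate means a step of a number no higher from compound 2 to compound 3 (the limit leaves the size open).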

Compound 3, half-maximal inhibitory concentration: > 200 ug/mL
Compound 3 was reported as a limit (the forecaster's own chance of this, stated with the estimate: 85%); the middle value sits exactly at the limit.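

Compound 3 gives > 200 ug/mL in this assay, which is a limit and not a number. The steps to compound 3 from compound 1 and from compound 2 therefore cannot be read, and all three compounds stand at the same place: the limit of > 200 ug/mL in this assay, at which 3 of the 3 values shown sit. On these data alone, whether these three compounds differ at all in strength, and what change to the shared core would give a measurable value, stays open.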